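The compounds below may be only part of what the source reports. "The series", "measured", "known", "first", "only" and "open" are said of these compounds alone.

Compound 3 `Cc1ccc(N2CCN(C(=O)[C@@H]3CN(C4CCOCC4)C[C@H]3c3ccc(Cl)cc3)CC2)c([C@@H](NC(=O)[C@H](C)N)C(C)C)c1` stands lowest of the three numbers measured in an assay on HEK293 cells for displacement of a labelled ligand from Melanocortin receptor 4 (Homo sapiens); on this read-out lower numbers stand for stronger inhibition and higher numbers for weaker inhibition: compound 3 gives 1 nM, compound 2 `Cc1ccc(N2CCN(C(=O)[C@@H]3CNC[C@H]3c3ccc(Cl)cc3)CC2)c([C@@H](NC(=O)CCN(C)C)C(C)C)c1` gives 7.2 nM and compound 1 `CC(=O)N1C[C@@H](C(=O)N2CCN(c3ccc(C)cc3[C@@H](NC(=O)CCN(C)C)C(C)C)CC2)[C@H](c2ccc(Cl)cc2)C1` gives 7.6 nM. Among the compounds with values here, the only single-point step measured, a 1.1-fold lower number from compound 1 to compound 2 (0.02 log units; within the scatter), concerns the ring amine nitrogen and does not bear on the change considered here. Compound 4 `Cc1ccc(N2CCN(C(=O)[C@@H]3CN(C4CCOCC4)C[C@H]3c3ccc(Cl)cc3)CC2)c([C@@H](NC(=O)CCN)C(C)C)c1` differs from compound 3 by 2-aminoethyl in place of 1-aminoethyl on a carbonyl carbon. Within the data shown here, compounds 1 and 2 differ from compound 3 in more than one place, so their values give no step for this change. Among the measured compounds shown here, no measured step in this assay speaks to moving the amine along the chain, so only a small step is expected for compound 4, a 2.0-fold higher number from compound 3 to compound 4 (0.30 log units; within the scatter). Compound 4 is therefore estimated at 2 nM, between 0.7 nM and 6 nM.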

Compound 4, inhibition constant: 2.2 nM
The estimate for compound 4 lay 1.1-fold (0.04 log units) below the measured number; the measured number falls inside the stated range.
By their numbers in this assay, from the lowest: compound 3; then compound 4; then compounds 2 and 1 (each within the scatter of the next).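

On a carbonyl carbon whose other neighbour is an amide-type nitrogen, the 2-aminoethyl in place of 1-aminoethyl change gives a 2.2-fold higher number from compound 3 to compound 4 (0.34 log units; beyond the scatter) in this assay, the first step read at this position, modest but beyond the scatter. The two groups have the same atoms, yet the change also removes the one defined stereocentre of 1-aminoethyl, so amine placement and stereocentre loss remain confounded. No supporting data explain the step. Open, from the compounds shown here alone, are the opposite stereocentre of 1-aminoethyl and whether a longer chain, such as 3-aminopropyl, would raise or lower the number further.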